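What One Methyl May Do to Compound 1

A few compounds are considered here, and "the series" means these few. Any claim that something is new, unique, unknown or untested is made for them only; others in the source may bear on it.

In an ADME assay on cells (Macrophage cell line, Homo sapiens) for cytotoxicity, read by MTT assay, with stated times of 24 h and 48 h (on this read-out lower numbers stand for stronger inhibition and higher numbers for weaker inhibition), compound 1 (`O=C(O)c1cc(-c2ccccc2)ncc1O`) gives 84500 nM as its reading. In this assay compound 2 (`COc1cccc(-c2cc(C(=O)O)c(O)cn2)c1`) gives 88600 nM as its reading, and these two numbers cannot be ranked against each other. The step between them is a 1.0-fold higher number from compound 1 to compound 2 (0.02 log units; within the scatter) and comes with methoxy in place of hydrogen on an aromatic carbon. Compound 3 (`O=C(O)c1ccnc(Cc2ccccc2)c1O`) gives > 100000 nM as a limit and not a number.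

Compound 4 (`Cc1nc(-c2ccccc2)cc(C(=O)O)c1O`) is still unmeasured. Its difference from compound 1 is methyl in place of hydrogen on an aromatic carbon and amounts to methyl in place of hydrogen on an aromatic carbon, next to the ring nitrogen and ortho to a hydroxy group. Within the data shown here, the one measured single-place step is small and involves a different group, so it offers only modest guidance. On that basis, no shift beyond the scatter is expected, and the estimated step is a 1.1-fold higher number from compound 1 to compound 4 (0.03 log units; within the scatter) at most a slight one. Compound 4 could also meet the limit of > 100000 nM in this assay, at which 1 of the 3 values shown sits, and return only a limit. Compound 4 is estimated at 90000 nM with an expected range from 50000 nM to 160000 nM in this measurement.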

Compound 4, half-maximal inhibitory concentration: 90800 nM
For compound 4 the middle estimate is 1.0-fold (0.00 log units) below the measured one; low and high end bracket the measured number.
By their numbers in this assay, from the lowest: compounds 1, 2 and 4 (each within the scatter of the next). At a limit, above all of these: compound 3.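

Methyl in place of hydrogen on an aromatic carbon, next to the ring nitrogen and ortho to a hydroxy group, alters a place that stays hydrogen in compound 1 and compound 2, and in this assay it gives a 1.1-fold higher number from compound 1 to compound 4 (0.03 log units; within the scatter). A single methyl at this place therefore leaves the reading within the scatter, so compound 4 becomes a second single-place change to compound 1 with that outcome, after the methoxy change in compound 2. The reading of compound 4 is a number, while compound 3 remains the only compound that returns a limit and not a number: the limit of > 100000 nM in this assay, at which 1 of the 4 values shown sits.

What the compounds shown leave open is whether this carbon would give the same outcome with a group other than methyl, such as an amine, a chlorine atom or a longer chain. They also leave open whether methyl at this place would behave in the same way on the core of compound 2, which carries the methoxy group.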